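Three Measured Clearances and a Trifluoromethyl Step Awaiting Data

This account rests on a few compounds, and the source may have more. Where it says the series, first, only, none or still open, it means among the compounds named here.

Compound 1 `O=C(N[C@@H]1CCCC[C@H]1O)c1cnc(OCC2CC2)c(-c2ccc(Cl)cc2)c1` gives 0.064 mL/min/kg in an ADME assay (liver) for pharmacokinetics, with Liver microsome (Rattus norvegicus) as the target, read by LC-MS, using microsomes, tested at 2 uM; on this read-out lower numbers stand for slow clearance and higher numbers for fast clearance.
Compound 2 `O=C(N[C@@H]1CCCC[C@H]1O)c1cnc(OCc2ccncc2)c(-c2ccc(Cl)cc2)c1` gives 0.118 mL/min/kg in this assay.
Compound 3 `O=C(N[C@@H]1CCCC[C@H]1O)c1cnc(OCC2CC2)c(-c2ccc(F)cc2)c1` gives 0.037 mL/min/kg in this assay.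

Of these three, the number for compound 3 and that for compound 1 lie within the scatter of each other, while compound 2 stands apart from compound 3 by a gap beyond the scatter. The two measured steps are both modest: a 1.8-fold higher number from compound 1 to compound 2 (0.27 log units; within the scatter), and a 1.7-fold lower number from compound 1 to compound 3 (0.24 log units; within the scatter). Neither step carries a clear signal.

Compound 4 `O=C(N[C@@H]1CCCC[C@H]1O)c1cnc(OCC2CC2)c(-c2ccc(C(F)(F)F)cc2)c1` has not yet been measured in this assay. It differs from compound 3 in one place: trifluoromethyl in place of fluoro on an aromatic carbon. Among the compounds with values here, the only measured step that touches this position is the exchange of fluoro for chloro between compound 1 and compound 3, which stayed within the scatter, so there is no measured footing for a large shift in either direction. The account therefore expects for compound 4 a number close to that of compound 3, with at most a small rise, which a 1.6-fold higher number from compound 3 to compound 4 (0.21 log units; within the scatter) expresses. Compound 4 is estimated at 0.06 mL/min/kg, within a range from 0.025 mL/min/kg to 0.15 mL/min/kg, and the measured value will tell whether the trifluoromethyl group moves the clearance beyond the scatter.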

Compound 4, clearance: 0.009 mL/min/kg
For compound 4 the middle estimate is 6.7-fold (0.82 log units) above the measured one; measured number below the stated range.
By their numbers in this assay, from the lowest: compound 4; then compounds 3, 1 and 2 (each within the scatter of the next, the first and the last beyond it).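

Within the data shown here, at the aromatic carbon para to a large group, the exchange between the two single halogens had stayed within the scatter, so the earlier compounds left open whether this position could move the number in this assay at all. Trifluoromethyl shows that it can, giving a 4.1-fold lower number from compound 3 to compound 4 (0.61 log units; beyond the scatter) and a 7.1-fold lower number from compound 1 to compound 4 (0.85 log units; beyond the scatter), with both steps beyond the scatter and both running towards slower clearance. The change replaces a single halogen atom with a group of four heavy atoms that adds no ring, hydrogen-bond donor, hydrogen-bond acceptor or net charge, but nothing measured here says what lies behind the lower number.

The compounds shown put only fluoro, chloro and trifluoromethyl on this carbon, so they do not tell how a nitrile, a methoxy group or a plain hydrogen there would read in this assay. They also leave open whether trifluoromethyl gives a step of similar size when the cyclopropyl group gives way to the pyridin-4-yl group of compound 2, as the step to compound 4 was read only with cyclopropyl in place.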